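This account rests on a few compounds, and the source may have more. Where it says the series, first, only, none or still open, it means among the compounds named here.

In an ADME assay on GM00637 cells (Homo sapiens) for cytotoxicity, read by MTT assay, with a stated time of 72 h (on this read-out higher numbers stand for weaker inhibition and lower numbers for stronger inhibition), compound 1 `O=c1ccc2nc(-c3ccccc3)nn(-c3ccccc3)c-2c1` gives 230 nM, compound 2 `CNc1cc2nc(-c3ccccc3)nn(-c3ccccc3)c-2cc1=O` gives 930 nM and compound 3 `O=c1cc2n(-c3ccccc3)nc(-c3ccccc3)nc-2cc1N1CCCC1` gives 1790 nM. Compound 3 thus stands within the scatter of compound 2 and clearly apart from compound 1. The next compound to read is compound 4 `CC(=O)Nc1cc2nc(-c3ccccc3)nn(-c3ccccc3)c-2cc1=O`, which carries acetamido in place of pyrrolidin-1-yl on an aromatic carbon. Two measured steps add a group at this carbon, a 4.0-fold higher number from compound 1 to compound 2 (0.61 log units; beyond the scatter) and a 7.8-fold higher number from compound 1 to compound 3 (0.89 log units; beyond the scatter), and both are modest and go to higher numbers. The exchange between those two groups, a 1.9-fold higher number from compound 2 to compound 3 (0.28 log units; within the scatter), stays within the scatter. Among the compounds with values here, no acetamido compound has been measured, so the closest guide is compound 2 at 930 nM, whose methylamino group is also attached through nitrogen. A step leaning to a lower number, but not beyond the scatter, is expected. The expected step in this assay is a 1.9-fold lower number from compound 3 to compound 4 (0.28 log units; within the scatter). For compound 4 the estimated value is 950 nM, with an expected range of 320 nM to 2600 nM.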

Compound 4, half-maximal inhibitory concentration: > 5000 nM
Compound 4: only a limit was reported; the forecaster's own chance of this, stated with the estimate: 3%; at least 5.2-fold (0.72 log units) between middle value and limit.
By their numbers in this assay, from the lowest: compound 1; then compounds 2 and 3 (each within the scatter of the next). At a limit, above all of these: compound 4.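

In this assay compound 4 is reported only as a limit, not as a number: the limit of > 5000 nM in this assay, at which 1 of the 4 values shown sits.

Methylamino and pyrrolidin-1-yl stand within the scatter of each other at this aromatic carbon, whereas acetamido separates from both, with an at least 2.7-fold higher number from compound 3 to compound 4 (0.44 log units; beyond the scatter) and an at least 5.3-fold higher number from compound 2 to compound 4 (0.73 log units; beyond the scatter), so the identity of the group on this nitrogen matters here and not only the presence of a substituent. Set against hydrogen at this carbon, the change gives an at least 21-fold higher number from compound 1 to compound 4 (1.33 log units; beyond the scatter), the first large step at this position, and all three substituents shown go to higher numbers, with no compound against that direction.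

As far as these compounds go, how far compound 4 lies past its limit remains unknown, so these three steps give only minimum sizes. From the compounds shown here alone, whether a primary amine, a longer acyl chain such as butyramido or a methanesulfonamido group at this carbon would read like acetamido or like methylamino remains open.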